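Swapping phenyl for methyl-oxazole in a weak adenosine series

A few compounds are considered here, and "the series" means these few. Any claim that something is new, unique, unknown or untested is made for them only; others in the source may bear on it.

Compound 2, with the structure `CCNC(=O)[C@H]1O[C@@H](n2cnc3c(NNC(=O)c4ccccc4)nc(Cl)nc32)[C@H](O)[C@@H]1O`, has been tested in an assay on CHO cells for displacement of a labelled ligand from adenosine receptor A1 (Homo sapiens); a higher number here means a weaker inhibitor, a lower number a stronger inhibitor. In this assay compound 2 gives only > 5000 nM, which is a limit of the assay rather than a measured number. Its closest relative, compound 1 with the structure `CCNC(=O)[C@H]1O[C@@H](n2cnc3c(NNC(=O)c4ccccc4)ncnc32)[C@H](O)[C@@H]1O`, differs by chloro in place of hydrogen on an aromatic carbon. In this assay compound 1 likewise gives > 5000 nM, again a limit. The step that the two limits leave unreadable from compound 1 to compound 2 therefore cannot be read, since both values sit at the limit of > 5000 nM in this assay, at which 2 of the 2 values shown sit.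

Compound 3, with the structure `CCNC(=O)[C@H]1O[C@@H](n2cnc3c(NNC(=O)c4cc(C)on4)nc(Cl)nc32)[C@H](O)[C@@H]1O`, is not yet measured. It differs from compound 2 by 5-methyl-1,2-oxazol-3-yl in place of phenyl on a carbonyl carbon. No measured pair shows this change, so no shown step bears on it directly, and the only measured step, a step that the two limits leave unreadable from compound 1 to compound 2, concerns a different change and is unreadable anyway. Because compound 2 sits at the limit of > 5000 nM in this assay, at which 2 of the 2 values shown sit, compound 3 is expected to remain at or near that limit. The step that the limit leaves unreadable from compound 2 to compound 3 is expected to be small. Compound 3 is estimated at 8000 nM, within a range from 2000 nM to 30000 nM.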

Compound 3, inhibition constant: > 5000 nM
Compound 3: only a limit was reported; the forecaster's own chance of this, stated with the estimate: 80%; the middle value is on the limit's open side.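

In this assay compound 2 and compound 3 both give only a limit, so no step can be read for 5-methyl-1,2-oxazol-3-yl in place of phenyl: the limit of > 5000 nM in this assay, at which 3 of the 3 values shown sit.

The compounds shown leave open how strong any of them truly is in this assay and whether either change alters that strength at all.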